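Cytotoxicity notes: pyridinyl in place of fluorophenyl

The source may report more compounds than this note shows. Statements on the series, on what has been measured and on what is new or still open speak of the compounds shown alone.

The series rests on the core of compound 1, `OC(c1ccc(Cl)cc1)(c1cncnc1)c1ccccc1F`. In an ADME assay on L6 cells (Rattus norvegicus) for cytotoxicity, read by resazurin assay, with a stated time of 72 h (a higher number here means a weaker inhibitor, a lower number a stronger inhibitor), compound 1 gives only a limit of the assay, > 100000 nM. Compound 2, `OC(c1ccc(Cl)cc1)(c1ccncn1)c1ccccc1Cl`, likewise gives only a limit in this assay, > 100000 nM. Going by the values given here, both measured values thus sit at the limit of > 100000 nM in this assay, at which 2 of the 2 values shown sit, and no measured step between any two compounds exists, so the data give no measured size for any change.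

Compound 3, `OC(c1ccc(Cl)cc1)(c1cccnc1)c1cncnc1`, differs from compound 1 by pyridin-3-yl in place of 2-fluorophenyl on a saturated chain carbon bound to two aromatic carbons and an oxygen on a saturated carbon. For this change, with both measured compounds at the limit and the shared core retained, the step that the limit leaves unreadable from compound 1 to compound 3 is expected to be none beyond the scatter. Compound 3 is accordingly estimated at 150000 nM, with a range from 50000 nM to 500000 nM, and is most likely to be reported again only as a limit rather than a number.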

Compound 3, half-maximal inhibitory concentration: > 100000 nM
Compound 3 gave a limit, no number; the forecaster's own chance of this, stated with the estimate: 85%; the middle value lies beyond the limit too.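

Going by these compounds alone, no step from compound 1 to compound 3 can be read in this assay since compound 1 and compound 3 each give only a limit: the limit of > 100000 nM in this assay, at which 3 of the 3 values shown sit. The compounds shown leave open whether any change on the shared core yields a numerical reading.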